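The source may hold more compounds than are shown below. What is called first, only, known or untested is meant among the compounds shown, and "the series" means these compounds.

In a functional assay on HEL cells (Homo sapiens) (on this read-out higher numbers stand for lower toxicity in this test and lower numbers for higher toxicity in this test), three compounds with a shared core have been measured. Compound 1 `Cc1cn([C@@H]2O[C@H](CO[Si](C)(C)C(C)(C)C)[C@@]3(OS(=O)(=O)C=C3NCC(=O)OCc3ccccc3)[C@H]2O[Si](C)(C)C(C)(C)C)c(=O)n(C)c1=O` reads > 200000 nM, which is a limit of the assay. Compound 2 `Cc1cn([C@@H]2O[C@H](CO[Si](C)(C)C(C)(C)C)[C@@]3(OS(=O)(=O)C=C3NCC(=O)C(=O)O)[C@H]2O[Si](C)(C)C(C)(C)C)c(=O)n(C)c1=O` gives 146000 nM, and the measured step is an at least 1.3-fold lower number from compound 1 to compound 2 (0.13 log units; that floor lies within the scatter). Compound 3 `Cc1cn([C@@H]2O[C@H](CO[Si](C)(C)C(C)(C)C)[C@@]3(OS(=O)(=O)C=C3NC(=O)NC(=O)c3ccccc3)[C@H]2O[Si](C)(C)C(C)(C)C)c(=O)n(C)c1=O` stands at >= 200000 nM, which is also a limit.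

Compound 4 `Cc1cn([C@@H]2O[C@H](CO[Si](C)(C)C(C)(C)C)[C@@]3(OS(=O)(=O)C=C3NCCC(=O)OCc3ccccc3)[C@H]2O[Si](C)(C)C(C)(C)C)c(=O)n(C)c1=O` carries 2-(benzyloxycarbonyl)ethyl in place of benzoylcarbamoyl on the amine nitrogen: 2-(benzyloxycarbonyl)ethyl in place of benzoylcarbamoyl on an amine nitrogen. Two measured steps change this same nitrogen substituent, namely a step that the two limits leave unreadable from compound 1 to compound 3 and an at least 1.3-fold higher number from compound 2 to compound 3 (0.13 log units; that floor lies within the scatter). Neither shows a change beyond the scatter, so no step beyond the scatter is expected in this assay.

Compound 4 is expected near 190000 nM, with an estimated range of 110000 nM to 280000 nM. The expected step is an at least 1.0-fold lower number from compound 3 to compound 4 (0.02 log units; that floor lies within the scatter).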

Compound 4, half-maximal cytotoxic concentration: 200000 nM
Estimate against measurement, compound 4: 1.1-fold (0.02 log units) below, and the stated range covers the measured number.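

In this assay, the 2-(benzyloxycarbonyl)ethyl group on the amine nitrogen gives compound 4 a plain measured number, not a limit, so this position now has a second readable value; in place of benzoylcarbamoyl, this group gives a number no higher from compound 3 to compound 4 (the limit leaves the size open). Going by these compounds alone, the only readable new step is a 1.4-fold higher number from compound 2 to compound 4 (0.14 log units; within the scatter), and it stays within the scatter, so this exchange shows no real change in toxicity in this test. The remaining new step is a number no higher from compound 1 to compound 4 (the limit leaves the size open). This step and the one from benzoylcarbamoyl cannot be read because each starts from a limit: the limit of > 200000 nM in this assay, at which 1 of the 4 values shown sits.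

Going by these compounds, whether a primary amine or a longer chain on this nitrogen would produce a step beyond the scatter remains open.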